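The source may report more compounds than this note shows. Statements on the series, on what has been measured and on what is new or still open speak of the compounds shown alone.

Measured compounds in an assay on isolated protein for inhibition of Aromatase (Homo sapiens), read by fluorescence and colorimetric assay, with a stated time of 30 min; a higher number here means a weaker inhibitor, a lower number a stronger inhibitor:
compound 1, `N#Cc1ccc(C(c2ccc(C#N)cc2)n2cc(COc3ccc([N+](=O)[O-])cc3)nn2)cc1`: 7730 nM
compound 2, `Cc1ccc(OCc2cn(C(c3ccc(C#N)cc3)c3ccc(C#N)cc3)nn2)cc1`: 11000 nM
compound 3, `O=[N+]([O-])c1ccc(OCc2cn(C(c3ccccc3)c3ccccc3)nn2)cc1`: 11600 nM

All three numbers lie within the usual scatter of one another. Compound 1 and compound 2 share a core and differ by methyl in place of nitro on an aromatic carbon; this change gave a 1.4-fold higher number from compound 1 to compound 2 (0.15 log units; within the scatter). Compound 3 carries another core; the difference between the two cores is not broken down here. Compound 4, `Cc1ccc(OCc2cn(C(c3ccccc3)c3ccccc3)nn2)cc1`, is not yet measured and differs from compound 3 by methyl in place of nitro on an aromatic carbon, the same change at the same place as between compound 1 and compound 2. For compound 4 a step of about a 1.4-fold higher number from compound 3 to compound 4 (0.14 log units; within the scatter) is expected because the same change gave a 1.4-fold higher number from compound 1 to compound 2 (0.15 log units; within the scatter) on the core of compound 1. Compound 4 is therefore estimated at 16000 nM in this assay, expected between 7000 nM and 36000 nM.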

Compound 4, half-maximal inhibitory concentration: 26800 nM
For compound 4 the middle estimate is 1.7-fold (0.22 log units) below the measured one, within the range that was stated.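

Methyl in place of nitro on the aromatic carbon gave a 2.3-fold higher number from compound 3 to compound 4 (0.36 log units; beyond the scatter) in this assay. The step on the second core cannot be told apart from the step on the first, so the change carries across these two cores within the scatter: the same change on two cores in this assay, a 1.4-fold higher number (0.15 log units; within the scatter) from compound 1 to compound 2 and a 2.3-fold higher number (0.36 log units; beyond the scatter) from compound 3 to compound 4, 1.6-fold (0.21 log units) apart, within the scatter of two such steps. This rests on a single pair per core and does not show that the step would hold on any further core; the step on the core of compound 1 also lies within the scatter on its own.

Still open, going by these compounds, is how an amine or a carboxylic acid would read in place of nitro or methyl at this ring position. On these data alone, how the difference between the two cores divides among its parts also remains open.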